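The source may hold more compounds than are shown below. What is called first, only, known or untested is meant among the compounds shown, and "the series" means these compounds.

Measured so far in a functional assay on A549 cells (Homo sapiens) for cytotoxicity, read by MTT assay, with a stated time of 72 h; on this read-out higher numbers stand for weaker inhibition and lower numbers for stronger inhibition
compound 1 `O=C(N/N=C/c1cccc(Br)c1)Nc1cc2c(Nc3ccc(F)c(Cl)c3)ncnc2cc1O[C@H]1CCOC1` gives 10700 nM
compound 2 `O=C(N/N=C/c1cccc(Cl)c1Cl)Nc1cc2c(Nc3ccc(F)c(Cl)c3)ncnc2cc1O[C@H]1CCOC1` gives 25000 nM
compound 3 `CCN(CC)c1ccc(/C=N/NC(=O)Nc2cc3c(Nc4ccc(F)c(Cl)c4)ncnc3cc2O[C@H]2CCOC2)c(O)c1` gives 15700 nM

On these numbers, compound 3 is separated from neither of the other two measured compounds (a 1.5-fold higher number from compound 1 to compound 3 (0.17 log units; within the scatter); a 1.6-fold lower number from compound 2 to compound 3 (0.20 log units; within the scatter)). Next in line is compound 4 `O=C(N/N=C/c1ccc(O)cc1)Nc1cc2c(Nc3ccc(F)c(Cl)c3)ncnc2cc1O[C@H]1CCOC1`, with 4-hydroxyphenyl in place of 4-(diethylamino)-2-hydroxyphenyl on a carbon with a double bond to nitrogen.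

All three measured steps are exchanges at this same place. The two that replace 4-(diethylamino)-2-hydroxyphenyl stay within the scatter, as shown above. For the measured compounds named here, the only step beyond the scatter is modest (a 2.3-fold higher number from compound 1 to compound 2 (0.37 log units; beyond the scatter)). Going by the values given here, no measured compound carries 4-hydroxyphenyl, so this group itself remains untested. No step beyond the scatter is therefore expected in this assay and no direction is favoured, giving an expected step of (a 1.0-fold lower number from compound 3 to compound 4 (0.02 log units; within the scatter)). The estimated value for compound 4 is 15000 nM (expected range 7000 nM to 32000 nM).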

Compound 4, half-maximal inhibitory concentration: 1320 nM
The estimate for compound 4 lay 11-fold (1.06 log units) above the measured number, outside the stated range (below it).
By their numbers in this assay, from the lowest: compound 4; then compounds 1, 3 and 2 (each within the scatter of the next, the first and the last beyond it).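

In this assay, the place on the carbon with a double bond to nitrogen proves able to carry much larger changes than the earlier exchanges suggested: 4-hydroxyphenyl gives a 12-fold lower number from compound 3 to compound 4 (1.08 log units; beyond the scatter), a 19-fold lower number from compound 2 to compound 4 (1.28 log units; beyond the scatter) and an 8.1-fold lower number from compound 1 to compound 4 (0.91 log units; beyond the scatter). A hydroxy group on the ring does not by itself go with the low number, as compound 3 also carries one yet stays within the scatter of compound 1 and compound 2; the step to compound 4 both removes the diethylamino group and changes where the hydroxy group stands, so the two changes cannot be separated. No measured data bear on why this group stands apart.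

As far as these compounds go, whether the hydroxy group is needed remains open, and an unsubstituted phenyl, 4-methoxyphenyl or 4-aminophenyl at this place would address that. A 2-hydroxyphenyl or 4-(diethylamino)phenyl would separate the two parts of the change from compound 3.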